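The compounds below may be only part of what the source reports. "The series", "measured", "known", "first", "only" and "open" are said of these compounds alone.

Of the compounds shown here, three of one series have been measured in an assay for inhibition of Polyunsaturated fatty acid 5-lipoxygenase (Homo sapiens), read by HPLC, with a stated time of 10 min; a higher number here means a weaker inhibitor, a lower number a stronger inhibitor. Compound 1 `CCCCC(Sc1ccc(OCCCOc2ccccc2OC)cc1)C(=O)O` gives only a limit of the assay, > 10000 nM. Compound 2 `CCCCC(Sc1ccc(OCCCOc2cccc3c2CCCC3)cc1)C(=O)OCC` also gives only a limit, > 10000 nM. Compound 3 `CCCCC(Sc1ccc(OCCCOc2ccc3ncccc3c2)cc1)C(=O)OCC` likewise gives a limit, > 10000 nM. Every value shown thus rests on (the limit of > 10000 nM in this assay, at which 3 of the 3 values shown sit), and compound 3 stands at that limit together with the other two. Among the compounds with values here, the only step that can be drawn between measured compounds, a step that the two limits leave unreadable from compound 2 to compound 3, cannot be read for size. Compound 4 `CCCCC(Sc1ccc(OCCCOc2ccc3ncccc3c2)cc1)C(=O)O` differs from compound 3 by hydrogen in place of ethyl on an oxygen next to a carbonyl group. Within the data shown here, no measured step bears directly on this change. Compound 1 carries the same carboxy group and sits at the limit. Compound 3 carries the ethoxycarbonyl group and sits at the limit as well. The step that the limit leaves unreadable from compound 3 to compound 4 is therefore expected to be none beyond the scatter. Compound 4 is expected to give about 15000 nM, within a range from 5000 nM to 60000 nM, and most likely to be reported again only as a limit.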

Compound 4, half-maximal inhibitory concentration: > 10000 nM
Compound 4: a limit, no number (the forecaster's own chance of this, stated with the estimate: 80%); the middle value is on the limit's open side.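

Compound 4 gives only a limit, as do compound 1 and compound 3, and neither the step from compound 3 to compound 4 nor the step from compound 1 to compound 4 can be read for size. The compounds shown leave open which change to the shared core, if any, would give a readable number: the limit of > 10000 nM in this assay, at which 4 of the 4 values shown sit.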